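Ring Amine Swap at the Shared Core: Compound 4

This account rests on a few compounds, and the source may have more. Where it says the series, first, only, none or still open, it means among the compounds named here.

In a functional assay on CHO-K1 cells for antagonist activity at transient receptor potential cation channel subfamily V member 1 (Homo sapiens), read by FLIPR (a higher number here means a weaker inhibitor, a lower number a stronger inhibitor), compound 3 `CC(C(=O)NCc1ccc(C(F)(F)F)nc1N1CCC(C(F)(F)F)CC1)c1ccc(NS(C)(=O)=O)c(F)c1` gives 0.6 nM, level with compound 2 `CC(C(=O)NCc1ccc(C(F)(F)F)nc1N1CCCC1)c1ccc(NS(C)(=O)=O)c(F)c1` at 0.6 nM and far from compound 1 `Cc1ccc(Nc2nc(C(F)(F)F)ccc2CNC(=O)C(C)c2ccc(NS(C)(=O)=O)c(F)c2)cc1C` at 39.3 nM. The steps of a 66-fold lower number from compound 1 to compound 2 (1.82 log units; beyond the scatter) and a 66-fold lower number from compound 1 to compound 3 (1.82 log units; beyond the scatter) show the large gain when a cyclic amine replaces the (3,4-dimethylphenyl)amino group; the step of no change at the digits printed from compound 2 to compound 3 (within the scatter) shows that the two cyclic amines are indistinguishable here. Compound 4 `CC(C(=O)NCc1ccc(C(F)(F)F)nc1N1CCN(C)CC1)c1ccc(NS(C)(=O)=O)c(F)c1` makes the change (4-methylpiperazin-1-yl in place of 4-(trifluoromethyl)piperidin-1-yl on an aromatic carbon). Among the compounds with values here, only the step from compound 2 to compound 3 bears on a swap between cyclic amines, and it was within the scatter, so no change beyond the scatter is expected in this assay, with a slight allowance for weakening since no ring with 2 hetero atoms has been tested. Compound 4 is therefore estimated at 1.5 nM (range 0.4 nM to 6 nM), a step of a 2.5-fold higher number from compound 3 to compound 4 (0.40 log units; beyond the scatter).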

Compound 4, inhibition constant: 146 nM
Compound 4: middle estimate off by 97-fold (1.99 log units), on the low side, outside the stated range (above it).
By their numbers in this assay, from the lowest: compounds 2 and 3 (each within the scatter of the next); then compound 1; then compound 4.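

In this assay the cyclic amines at this position are not interchangeable: the change gives a 240-fold higher number from compound 3 to compound 4 (2.39 log units; beyond the scatter) and likewise a 240-fold higher number from compound 2 to compound 4 (2.39 log units; beyond the scatter). The 4-methylpiperazin-1-yl group also falls behind (3,4-dimethylphenyl)amino, with a 3.7-fold higher number from compound 1 to compound 4 (0.57 log units; beyond the scatter), so a cyclic amine as such does not secure the gain seen with compound 2 and compound 3. No measurement shown accounts for this loss.

Open: whether the loss follows the added ring nitrogen or the methyl group on it. Morpholine or unsubstituted piperazine at this position would separate the two.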